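This account rests on a few compounds, and the source may have more. Where it says the series, first, only, none or still open, it means among the compounds named here.

For the measured compounds named here, in a functional assay on HCC70 cells (Homo sapiens) for antiproliferative activity, read by crystal violet staining, with a stated time of 96 h (on this read-out lower numbers stand for an effect already at smaller amounts and higher numbers for an effect only at larger amounts of compound), compound 1 `O[C@@H]1[C@@H](O)[C@H](Oc2ccc3ccccc3c2)OC[C@H]1F` gives 37 uM, the lower of the two numbers so far, and compound 2 `O[C@H]1[C@H](Oc2ccc3ccccc3c2)OC[C@@H](O)[C@@H]1F` gives 94 uM, a gap beyond the usual scatter. Compound 3 `O[C@H]1[C@H](Oc2ccc3ccccc3c2)OCC[C@@H]1O` has not yet been measured. It differs from compound 1 by hydrogen in place of fluoro on a saturated ring carbon. Going by the values given here, no measured pair shows this swap alone, so the guidance is thin. In this assay, a small rise in the number is expected, hardly beyond the scatter. The expected change is a 1.4-fold higher number from compound 1 to compound 3 (0.13 log units; within the scatter). For compound 3, the estimated value is 50 uM, with a range of 20 uM to 120 uM.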

Compound 3, concentration for half-maximal effect: 284 uM
Compound 3: middle estimate off by 5.7-fold (0.75 log units), on the low side; measured number above the stated range.
By their numbers in this assay, from the lowest: compound 1; then compound 2; then compound 3.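

Replacing fluoro with hydrogen on this saturated ring carbon brings a 7.7-fold higher number from compound 1 to compound 3 (0.89 log units; beyond the scatter) in this assay. This single swap therefore has a clear effect, and the fluoro at this position goes with the lower number in this pair. No measurement shown here explains why the step is this large. On these data alone, whether chloro, methoxy or an amine at this position would keep a number as low as that of compound 1 stays open. So does whether the same swap would have a step of similar size on another core.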